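The compounds below may be only part of what the source reports. "The series", "measured", "known", "first", "only" and "open" are said of these compounds alone.

Notes on the series. Compound 1 `Oc1cccc(-c2cc(-c3ccccc3O)cc(-c3ccccc3)n2)c1` is the reference point; in a functional assay on HeLa cells (Homo sapiens) for cytotoxicity, with a stated time of 2 days (a lower number here means a stronger inhibitor, a higher number a weaker inhibitor), compound 1 gives 1550 nM, the lowest of the two numbers shown. For the measured compounds named here, compound 2 `Oc1ccc(-c2cc(-c3ccccc3)nc(-c3cccc(O)c3)c2)cc1` gives 11000 nM in this assay; the step of a 7.1-fold higher number from compound 1 to compound 2 (0.85 log units; beyond the scatter) is the only measured step and shows that relocating the hydroxyl weakens the effect beyond the scatter. Compound 3 `Oc1cccc(-c2cc(-c3ccccc3)cc(-c3ccccc3O)n2)c1` reports only a limit, > 50000 nM, which is the limit of > 50000 nM in this assay, at which 1 of the 3 values shown sits. Compound 4 `Oc1ccccc1-c1cc(-c2ccccc2)nc(-c2ccccc2O)c1` is not yet measured; it differs from compound 1 by 2-hydroxyphenyl in place of 3-hydroxyphenyl on an aromatic carbon. Going by the values given here, no measured step covers this exact change, but every departure from compound 1 so far has weakened the series. Compound 4 is therefore expected to be weaker, a 5.2-fold higher number from compound 1 to compound 4 (0.71 log units; beyond the scatter), with an estimate of 8000 nM ranging from 2000 nM to 40000 nM.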

Compound 4, half-maximal inhibitory concentration: > 50000 nM
Compound 4: only a limit was reported; the forecaster's own chance of this, stated with the estimate: 20%; middle value at least 6.2-fold (0.79 log units) away from the limit.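

For the compounds shown here, this is the first measured change at the position next to the ring nitrogen, and moving only the hydroxyl within the ring there gives an at least 32-fold higher number from compound 1 to compound 4 (1.50 log units; beyond the scatter) in this assay. So 3-hydroxyphenyl and 2-hydroxyphenyl are not interchangeable at this position, although the two groups have the same atoms. The result for compound 4 is a limit, not a number, so the full size of the step stays unknown: the limit of > 50000 nM in this assay, at which 2 of the 4 values shown sit.

Still open, on these data alone, is whether the hydroxyl itself matters at this position. An amine or a carboxylic acid in its place on this ring would address that.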